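The source may hold more compounds than are shown below. What is called first, only, known or untested is meant among the compounds shown, and "the series" means these compounds.

Compound 3 `CCCCNCC(O)COc1cc(=O)oc2ccccc12` stands at the edge of what the readout can report. In an ADME assay on Vero cells (Chlorocebus sabaeus) for cytotoxicity, read by fluorescence and resazurin assay, with a stated time of 72 h (a lower number here means that less compound is tolerated, a higher number that more compound is tolerated), compound 3 gives > 100000 nM, a limit of the assay rather than a number. In this assay compound 1 `Cc1ccc(NCC(O)COc2cc(=O)oc3ccccc23)cc1` gives > 100000 nM, again a limit. In this assay compound 2 `O=c1cc(OCC(O)CNC2CC2)c2ccccc2o1` gives > 100000 nM, a limit as well. The steps a step that the two limits leave unreadable from compound 1 to compound 2, a step that the two limits leave unreadable from compound 1 to compound 3 and a step that the two limits leave unreadable from compound 2 to compound 3 cannot be sized because of the limit of > 100000 nM in this assay, at which 3 of the 3 values shown sit. Compound 4 `CN1CCN(CC(O)COc2cc(=O)oc3ccccc23)CC1` differs from compound 3 by 4-methylpiperazin-1-yl in place of butylamino on a saturated chain carbon, two bonds along the chain from an oxygen on a saturated carbon. Since every measured step at this amine nitrogen is hidden by the limit, no direction can be read for this assay, and compound 4 is expected to sit at 120000 nM, within 50000 nM to 300000 nM. The expected step is therefore a step that the limit leaves unreadable from compound 3 to compound 4, most likely reported only as a limit once more.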

Compound 4, half-maximal cytotoxic concentration: > 100000 nM
Compound 4: no number, only a limit (the forecaster's own chance of this, stated with the estimate: 80%); the middle value does not contradict the limit.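

The steps from compound 1, compound 2 and compound 3 to compound 4 cannot be read in this assay, as all four compounds stand at a limit: the limit of > 100000 nM in this assay, at which 4 of the 4 values shown sit.

The compounds shown leave open whether changing the group on the amine nitrogen alters how much compound is tolerated.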